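This account rests on a few compounds, and the source may have more. Where it says the series, first, only, none or still open, it means among the compounds named here.

Of the compounds shown here, two sharing one core have been measured in a functional assay on SW1573 cells (Homo sapiens) for inhibition, read by sulforhodamine B assay, with a stated time of 48 h; on this read-out lower numbers stand for stronger inhibition of growth and higher numbers for weaker inhibition of growth. Compound 1 `O=C(/C(=C/c1ccc(Cl)cc1Cl)CCl)c1ccccc1` gives 3800 nM, while compound 2 `CCC(/C=C(\COC(C)=O)C(=O)c1ccccc1)CC` gives 77000 nM, the highest of the two numbers and separated from compound 1 by a gap beyond the scatter. Compound 3 `CC(=O)OC/C(=C\c1ccc(F)cc1)C(=O)c1ccccc1` differs from compound 2 by 4-fluorophenyl in place of pentan-3-yl on a double-bonded chain carbon bound to a double-bonded chain carbon. Among the compounds with values here, no measured pair shows this exact change; since compound 1, which carries an aromatic ring at that position, gives 3800 nM, the return to an aromatic ring is expected to lower the number in this assay beyond the scatter, by an expected step of a 7.7-fold lower number from compound 2 to compound 3 (0.89 log units; beyond the scatter). Compound 3 is therefore estimated at 10000 nM, within 3000 nM to 40000 nM.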

Compound 3, concentration for 50% growth inhibition: 4200 nM
The estimate for compound 3 lay 2.4-fold (0.38 log units) above the measured number; low and high end bracket the measured number.
By their numbers in this assay, from the lowest: compounds 1 and 3 (each within the scatter of the next); then compound 2.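

In this assay the change from pentan-3-yl to 4-fluorophenyl on a double-bonded chain carbon bound to a double-bonded chain carbon gives an 18-fold lower number from compound 2 to compound 3 (1.26 log units; beyond the scatter) as a large step. Within the data shown here, this is the first reading of a single change at this position, and it shows that the number responds strongly to the group placed there. No evidence on hand explains the step.

The compounds shown leave open whether the fluorine contributes anything beyond the ring itself, and how an unsubstituted phenyl or a pyridine ring would read at this position.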